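This account rests on a few compounds, and the source may have more. Where it says the series, first, only, none or still open, it means among the compounds named here.

Among the measured compounds shown here, in a functional assay on SK-MEL-2 cells (Homo sapiens) for cytotoxicity (on this read-out lower numbers stand for stronger inhibition and higher numbers for weaker inhibition), compound 2 (`O=C1NC(c2ccccc2)CN1S(=O)(=O)c1ccccc1`) gives 116000 nM, the only actual number so far. Compound 1 (`Cc1ccc(C2CN(S(=O)(=O)c3ccccc3)C(=O)N2)cc1`) reaches only a limit, > 316000 nM. Compound 3 (`O=C1NC(c2ccccc2)CN1S(=O)(=O)c1ccc(Cl)cc1`) carries one change: chloro in place of hydrogen on an aromatic carbon. For the measured compounds named here, the one measured step, an at least 2.7-fold lower number from compound 1 to compound 2 (0.43 log units; beyond the scatter), concerns a methyl on a different aromatic ring, so it bears only loosely on this change. No clear shift beyond the scatter is therefore expected in this assay, and the expected step is a 1.1-fold lower number from compound 2 to compound 3 (0.02 log units; within the scatter). Compound 3 is estimated at 110000 nM, within an expected range of 35000 nM to 316000 nM.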

Compound 3, half-maximal inhibitory concentration: 1430 nM
Beside the measured number, compound 3's estimate is 77-fold (1.89 log units) above it; the measured number lies below the stated range.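

Among the compounds shown here, the change of phenyl to 4-chlorophenyl, with an 81-fold lower number from compound 2 to compound 3 (1.91 log units; beyond the scatter) in this assay, shows that one chlorine at this place, para to a large group, can move the read-out by a large step, which the earlier compounds gave no sign of. Compound 1 remains a limit, so the methyl step on the other ring has no fixed size: the limit of > 316000 nM in this assay, at which 1 of the 3 values shown sits. The compounds shown leave open whether this step is particular to chloro, or whether fluoro, bromo, methoxy or an amine at this place would give the same. They also leave open what chloro would do at another carbon of this ring or on the other ring.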